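A few compounds are considered here, and "the series" means these few. Any claim that something is new, unique, unknown or untested is made for them only; others in the source may bear on it.

Measured so far in this series:

compound 1 `O=C(Nc1cccnc1)c1ccccc1Cl` — > 3000 nM
compound 2 `CC[C@@H]1c2cc(Cl)ccc2C(=O)N1c1cncc2c1CCC[C@H]2NC(C)=O` — 334 nM
compound 3 `CCC(=O)N[C@@H]1CCCc2c1cncc2N1CCc2cc(Cl)ccc2C1=O` — 3330 nM

In an ADME assay on cells for inhibition of cytochrome P450 11B1, mitochondrial (Homo sapiens), read by HTRF (on this read-out lower numbers stand for stronger inhibition and higher numbers for weaker inhibition), compound 1 gives > 3000 nM, which is a limit of the assay and not a number (the limit of > 3000 nM in this assay, at which 1 of the 3 values shown sits). Compound 2 gives 334 nM, the lowest of the two numbers recorded in this assay. Compound 3 gives 3330 nM, a higher number than that of compound 2, and the gap between the two lies beyond the scatter of the assay.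

Compound 4 `CC(=O)N[C@@H]1CCCc2c1cncc2N1C(=O)c2ccc(Cl)cc2[C@H]1C1CC1` is not yet measured in this assay. It differs from compound 2 in one place: cyclopropyl in place of ethyl on a saturated ring carbon. Among the compounds with values here, no pair of measured compounds shows this exchange, so no measured step guides the expectation. The exchange is a small one, and the step expected in this assay is a 1.2-fold lower number from compound 2 to compound 4 (0.09 log units; within the scatter), a change not clearly beyond the scatter in either direction. Compound 4 is therefore estimated at 270 nM, with a range from 100 nM to 750 nM.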

Compound 4, half-maximal inhibitory concentration: 22800 nM
For compound 4 the middle estimate is 84-fold (1.93 log units) below the measured one, and the stated range ends below it.
By their numbers in this assay, from the lowest: compound 2; then compound 3; then compound 4.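

In this assay, the group on the saturated ring carbon next to the ring nitrogen has a large effect on the read-out: cyclopropyl in place of ethyl gives a 68-fold higher number from compound 2 to compound 4 (1.83 log units; beyond the scatter). The exchange is small, from ethyl with 2 heavy atoms to cyclopropyl with 3 heavy atoms, with no hydrogen-bond donor or acceptor on either side, yet it moves inhibition well beyond the scatter towards the weaker end. Within the data shown here, nothing measured so far bears on what lies behind the size of this step.

A propyl or isopropyl group at this carbon would help separate the effect of the three-membered ring from that of the added carbon. Going by these compounds, how a smaller methyl group or an amine would read at this carbon also remains open.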